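Aryl ketone variation at the carbonyl carbon

The source may report more compounds than this note shows. Statements on the series, on what has been measured and on what is new or still open speak of the compounds shown alone.

Compound 2 `COc1cc(-c2nnc3n2NC(c2ccco2)C(C(=O)c2cccc(Br)c2)S3)cc(OC)c1OC` stands as the only numerical result in this set, giving 36900 nM in a functional assay on A549 cells (Homo sapiens) for cytotoxicity, read by MTT assay, with a stated time of 48 h; on this read-out higher numbers stand for weaker inhibition and lower numbers for stronger inhibition. Compound 1 `COc1cc(-c2nnc3n2NC(c2ccco2)C(C(=O)C2CC2)S3)cc(OC)c1OC` sits at the limit of the assay, > 100000 nM. Compound 3 `COc1ccc(C(=O)C2Sc3nnc(-c4cc(OC)c(OC)c(OC)c4)n3NC2c2cccs2)cc1` likewise sits at the limit, > 100000 nM. For the measured compounds named here, the one measured step, an at least 2.7-fold lower number from compound 1 to compound 2 (0.43 log units; beyond the scatter), rests on the limit of > 100000 nM in this assay, at which 2 of the 3 values shown sit, at its start and so only bounds the gain. Compound 4 `COc1cc(-c2nnc3n2NC(c2ccco2)C(C(=O)c2ccccc2C)S3)cc(OC)c1OC` carries the change (2-methylphenyl in place of 3-bromophenyl on a carbonyl carbon). Going by the values given here, no measured step swaps one aryl group for another on that carbonyl carbon, so the direction rests on thin data, with compound 3 showing that another aryl ketone can sit at the limit. A step of a 1.6-fold higher number from compound 2 to compound 4 (0.21 log units; within the scatter) toward weaker inhibition is expected. Compound 4 is estimated at 60000 nM, between 25000 nM and 130000 nM.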

Compound 4, half-maximal inhibitory concentration: 80000 nM
Estimate against measurement, compound 4: 1.3-fold (0.12 log units) below; low and high end bracket the measured number.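

On the carbonyl carbon, one aryl group can now be read against another in this assay: 2-methylphenyl in place of 3-bromophenyl gives a 2.2-fold higher number from compound 2 to compound 4 (0.34 log units; beyond the scatter). Against cyclopropyl, 2-methylphenyl gives only a bounded step, an at least 1.2-fold lower number from compound 1 to compound 4 (0.09 log units; that floor lies within the scatter), so compound 4 is not separated from compound 1. That step starts from a limit, not a number: the limit of > 100000 nM in this assay, at which 2 of the 4 values shown sit.

Still open, going by these compounds, is whether the step follows the bromine or the methyl, and the place of each on the ring. A 2-bromophenyl or 3-methylphenyl group on that carbonyl carbon would separate these.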